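The source may hold more compounds than are shown below. What is called first, only, known or untested is meant among the compounds shown, and "the series" means these compounds.

Measured compounds:

Compound 1, `C[C@@H]1CN(Cc2ccccc2)c2ncccc2[C@H](C)N1C(=O)NCc1ccccc1`: 15 nM
Compound 2, `C[C@@H]1CN(Cc2ccccc2)c2cncc(F)c2[C@H](C)N1C(=O)Nc1cccnc1`: 107 nM
Compound 3, `COc1ccc(CNC(=O)N2[C@H](C)CN(Cc3ccc(C(F)(F)F)o3)c3cnccc3[C@@H]2C)cc1`: 13 nM

Of the compounds shown here, three sharing a core have been measured in an assay on HEK293 cells for inhibition of Voltage-dependent T-type calcium channel subunit alpha-1G (Homo sapiens), read by FLIPR and calcium flux, with a stated time of 3 min; a lower number here means a stronger inhibitor, a higher number a weaker inhibitor. Compound 1 gives 15 nM, which is the second highest of the three numbers. Compound 3 sits nearest to it with 13 nM, a gap within the scatter, so the two cannot be told apart. Compound 2, with 107 nM, stands furthest from compound 1, and that gap lies beyond the scatter. For the measured compounds named here, compound 2 carries other changes beside a fluorine, so no single step to compound 1 can be read from it.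

The unmeasured compound 4, `C[C@@H]1CN(Cc2ccccc2)c2nc(F)ccc2[C@H](C)N1C(=O)NCc1ccccc1`, differs from compound 1 in one place: fluoro in place of hydrogen on an aromatic carbon. Going by the values given here, no pair of measured compounds separated by this change alone is available, so the size of the step is uncertain. Given that compound 1 shows 15 nM and a single fluorine is a small change, the step from compound 1 to compound 4 in this assay is expected to be small and within the scatter, with no clear direction, as a 1.2-fold higher number from compound 1 to compound 4 (0.08 log units; within the scatter). Compound 4 is therefore estimated at 18 nM, between 7 nM and 45 nM.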

Compound 4, half-maximal inhibitory concentration: 7 nM
Compound 4: middle estimate off by 2.6-fold (0.41 log units), on the high side; measured number inside the range.
By their numbers in this assay, from the lowest: compounds 4, 3 and 1 (each within the scatter of the next, the first and the last beyond it); then compound 2.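

In this assay, fluoro in place of hydrogen on an aromatic carbon, next to the ring nitrogen, gives a 2.1-fold lower number from compound 1 to compound 4 (0.33 log units; beyond the scatter), a modest step just beyond the scatter. For the compounds shown here, this is the first change in a single place that can be read, and it shows that this position accepts a fluorine with no loss of inhibition and a small gain. No measurement at hand bears on what lies behind this step.

A single pair cannot show whether the step would persist in compounds that differ elsewhere from compound 1. As far as these compounds go, it also remains open how larger or different groups at this position, such as chloro, methoxy, a nitrile or an amine, would compare with hydrogen and fluoro.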